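Extending the ring-nitrogen chain of compound 1 by an aminomethyl group

This account rests on a few compounds, and the source may have more. Where it says the series, first, only, none or still open, it means among the compounds named here.

Measured compounds:
compound 1, `CCN1C(=O)NC2(CSC3=C2C(=O)c2ccccc2C3=O)C1=O`, 116 nM
compound 2, `O=C1C2=C(C(=O)c3ccccc31)C1(CS2)NC(=O)N(CCCO)C1=O`, 40 nM
compound 3, `NCCN1C(=O)NC2(CSC3=C2C(=O)c2ccccc2C3=O)C1=O`, 22 nM; 20 nM; 31 nM (3 entries)

In a functional assay on MCF7 cells (Homo sapiens) for inhibition (on this read-out lower numbers stand for stronger inhibition and higher numbers for weaker inhibition), compound 1 gives the highest of the two single numbers shown; its nearest neighbour is compound 2, and the step is a 2.9-fold lower number from compound 1 to compound 2 (0.46 log units; beyond the scatter). Compound 3 returns the repeated readings (the several entries of compound 3 in this assay, 22 nM; 20 nM; 31 nM (3 entries)), which also fall under compound 1. Compound 4, `NCCCN1C(=O)NC2(CSC3=C2C(=O)c2ccccc2C3=O)C1=O`, differs from compound 1 by aminomethyl in place of hydrogen on a saturated chain carbon, two bonds along the chain from an amide-type nitrogen in a ring. Among the measured compounds shown here, the one measured step at this place, a 2.9-fold lower number from compound 1 to compound 2 (0.46 log units; beyond the scatter), introduced a hydroxymethyl group there and gave a modest lowering; the present change introduces an aminomethyl group, and a step of comparable size and direction is expected, so that a 2.9-fold lower number from compound 1 to compound 4 (0.46 log units; beyond the scatter) is estimated. Compound 4 is therefore expected to give about 40 nM in this assay, within a range of 15 nM to 110 nM.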

Compound 4, half-maximal inhibitory concentration: 25 nM
The estimate for compound 4 lay 1.6-fold (0.20 log units) above the measured number, and the stated range covers the measured number.
By their numbers in this assay, from the lowest: compounds 4 and 2 (each within the scatter of the next); then compound 1.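

In this assay, 3-aminopropyl in place of ethyl gives a 4.6-fold lower number from compound 1 to compound 4 (0.67 log units; beyond the scatter), so a terminal amine on this chain lowers the number, as the terminal hydroxy group of compound 2 did. Amino in place of hydroxy gives a 1.6-fold lower number from compound 2 to compound 4 (0.20 log units; within the scatter), so the two chain ends cannot be told apart here. Compound 3, with the shorter 2-aminoethyl chain, reads in the same range as compound 4: the several entries of compound 3 in this assay, 22 nM; 20 nM; 31 nM (3 entries)

The compounds shown leave open how a carboxylic acid or a dimethylamine at the chain end would read. They also leave open whether a longer chain carrying the amine would keep these numbers.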